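The compounds below may be only part of what the source reports. "The series", "measured", "known", "first", "only" and "open" are said of these compounds alone.

Measured so far in an assay for binding affinity to dual specificity mitogen-activated protein kinase kinase 4 (Homo sapiens), read by KINOMEscan, tested at 100 nM; a lower number here means a stronger effect, a higher number a weaker effect of the compound at the concentration tested:
compound 1 `CCCS(=O)(=O)Nc1ccc(F)c(C(=O)c2n[nH]c3ncc(-c4ccc(N)cc4)cc23)c1F` — 0.1%
compound 2 `CCCS(=O)(=O)Nc1ccc(F)c(C(=O)c2n[nH]c3ncc(-c4ccc(F)cc4C)cc23)c1F` — 14%

Compound 2 stands highest of the two numbers in this assay; its nearest neighbour is compound 1, and the step of a number 13.9 percentage points higher from compound 1 to compound 2 (beyond the scatter) lies beyond the scatter.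

Compound 3 `CCCS(=O)(=O)Nc1ccc(F)c(C(=O)c2n[nH]c3ncc(-c4ccc(S(C)(=O)=O)cc4)cc23)c1F` is not yet measured. It differs from compound 2 by 4-(methylsulfonyl)phenyl in place of 4-fluoro-2-methylphenyl on an aromatic carbon.

Among the measured compounds shown here, only the step from compound 1 to compound 2 bears on this change, and only in part, since it swaps the whole aryl group rather than one substituent. It was modest in size. Compound 3 is therefore expected to give a number lower than compound 2, by a number 11 percentage points lower from compound 2 to compound 3 (beyond the scatter), and the estimate for compound 3 in this assay is 3%, in a range from 0.1% to 20%.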

Compound 3, a percentage reported as activity, at one concentration (the size of the read-out at that concentration, not a potency): 1.5%
Compound 3: the middle estimate sits 1.5 percentage points above what was measured; low and high end bracket the measured number.
By their numbers in this assay, from the lowest: compounds 1 and 3 (each within the scatter of the next); then compound 2.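

At this aromatic carbon of the shared core, 4-(methylsulfonyl)phenyl in place of 4-fluoro-2-methylphenyl gives a number 12.5 percentage points lower from compound 2 to compound 3 (beyond the scatter) in this assay, while methylsulfonyl in place of amino gives a number 1.4 percentage points higher from compound 1 to compound 3 (within the scatter), so the low number of compound 1 does not depend on the amino group alone. The step from compound 2 changes both the fluoro and methyl substituents at once and cannot be assigned to either. No measured evidence explains these differences.

Open, on these data alone, is how a plain phenyl, 4-fluorophenyl or 2-methylphenyl group would read here. Also open, as far as these compounds go, is whether a carboxylic acid on the same ring would keep the number low.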